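Swapping Benzyl for 4-Methylphenyl on an Amide-Type Nitrogen

This account rests on a few compounds, and the source may have more. Where it says the series, first, only, none or still open, it means among the compounds named here.

Compound 1 `Cc1ccc(NC(=O)CCN(Cc2ccc(C(=O)NO)cc2)C(=O)c2cc(C)cc(C)c2)cc1` gives 370 nM
Compound 2 `Cc1ccc(NC(=O)CCN(Cc2ccc(C(=O)NO)cc2)C(=O)c2ccccc2)cc1` gives 540 nM
Compound 3 `CN(C)c1ccc(C(=O)N(CCC(=O)NCc2ccccc2)Cc2ccc(C(=O)NO)cc2)cc1` gives 1150 nM

All three numbers come from a functional assay on G55T2 cells (Homo sapiens) for antiproliferative activity, read by WST assay, with a stated time of 72 h (on this read-out lower numbers stand for stronger inhibition and higher numbers for weaker inhibition), and compound 4 `Cc1ccc(NC(=O)CCN(Cc2ccc(C(=O)NO)cc2)C(=O)c2ccc(N(C)C)cc2)cc1` has not yet been measured there. Compound 3 holds the highest number of the three, and its gaps to the other two lie beyond the scatter. Compound 4 has the same atoms as compound 3, joined differently, with 4-methylphenyl in place of benzyl on an amide-type nitrogen. For the measured compounds named here, the only measured single change (a 1.5-fold higher number from compound 1 to compound 2 (0.16 log units; within the scatter)) lies elsewhere, on a carbonyl carbon, and stays within the scatter, so it offers only indirect guidance. Compound 2 at 540 nM and compound 1 at 370 nM both carry 4-methylphenyl, although they also differ from compound 3 in a second place. A modest move toward a lower number is therefore expected, and the estimated step is a 2.1-fold lower number from compound 3 to compound 4 (0.32 log units; beyond the scatter) in size. For compound 4 the estimated value is 550 nM with an expected range of 230 nM to 1300 nM overall.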

Compound 4, half-maximal inhibitory concentration: 330 nM
Compound 4: middle estimate off by 1.7-fold (0.22 log units), on the high side, and the stated range covers the measured number.
By their numbers in this assay, from the lowest: compounds 4, 1 and 2 (each within the scatter of the next); then compound 3.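

In this assay, for the compounds shown here, 4-methylphenyl in place of benzyl on the amide-type nitrogen gives a 3.5-fold lower number from compound 3 to compound 4 (0.54 log units; beyond the scatter), so this is the first single change here that clears the scatter, and it does so between two groups with the same count of carbon atoms. On the carbonyl side, dimethylamino in place of hydrogen on an aromatic carbon gives a 1.6-fold lower number from compound 2 to compound 4 (0.21 log units; within the scatter), and 4-(dimethylamino)phenyl in place of 3,5-dimethylphenyl gives a 1.1-fold lower number from compound 1 to compound 4 (0.05 log units; within the scatter), so neither change stands out from the scatter. Nothing measured here accounts for the size of the step at the nitrogen.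

Still open, going by these compounds, is how plain phenyl, 4-chlorophenyl or 2-phenylethyl, a longer chain, would read on that same nitrogen. Also open, on these data alone, is whether the swap keeps its size with a different group on the carbonyl carbon.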